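The source may hold more compounds than are shown below. What is called first, only, known or untested is meant among the compounds shown, and "the series" means these compounds.

Working notes on the series. In a functional assay on HCT-116 cells (Homo sapiens) for inhibition, read by MTT assay, with a stated time of 72 h, tested at 20 uM (on this read-out lower numbers stand for less inhibition and higher numbers for more inhibition at the one concentration tested (going by the name of the read-out)), compound 2 `c1cc(N2CCCCC2)nc(Nc2ccc(Oc3ncnc4sccc34)cc2)n1` gives 66.3%. Among the compounds with values here, compound 1 `CNC(=O)c1cc(Oc2ccc(Nc3nccc(N4CCCC4)n3)cc2)ccn1` gives 66.4% in this assay, a number within the scatter of that of compound 2, so compound 2 stands level with the only other measured compound. Compound 3 `CNC(=O)c1cc(Oc2ccc(Nc3nccc(N4CCCCC4)n3)cc2)ccn1` differs from compound 2 by a group of 10 heavy atoms (7 carbon, 2 nitrogen, 1 oxygen; one six-membered aromatic ring with 1 hetero atom) in place of a group of 9 heavy atoms (6 carbon, 2 nitrogen, 1 sulfur; one five-membered aromatic ring with 1 hetero atom, one six-membered aromatic ring with 2 hetero atoms), on an oxygen on an aromatic ring. Within the data shown here, no step between measured compounds is known here. Because compound 1 with the same entering group gives 66.4% in this assay, the expected step is a number 0.3 percentage points lower from compound 2 to compound 3 (within the scatter), none beyond the scatter. Compound 3 is expected to give 66% in this assay, between 52% and 80%.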

Compound 3, a percentage reported as inhibition, at one concentration (the size of the read-out at that concentration, not a potency): 69.8%
Beside the measured number, compound 3's estimate is 3.8 percentage points below it; the measured number falls inside the stated range.
By their numbers in this assay, from the lowest: compounds 2, 1 and 3 (each within the scatter of the next).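

In this assay the step of a number 3.5 percentage points higher from compound 2 to compound 3 (within the scatter) comes with 2-(methylcarbamoyl)pyridin-4-yl entering on an oxygen on an aromatic ring, so this large exchange of groups leaves the read-out level. Piperidin-1-yl in place of pyrrolidin-1-yl on an aromatic carbon gives a number 3.4 percentage points higher from compound 1 to compound 3 (within the scatter) and is likewise not a readable change. No measurement on hand bears on either step. Going by these compounds, whether morpholin-4-yl or an open-chain dimethylamino group on that aromatic carbon would also stay level remains open. A reading at a single concentration also leaves the potency of all three compounds open.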